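This account rests on a few compounds, and the source may have more. Where it says the series, first, only, none or still open, it means among the compounds named here.

Measured so far:
Compound 1 `CC(C)=CC[C@@H](OC(=O)C1CCOC1)C1=CC(=O)c2c(O)ccc(O)c2C1=O` gives 73500 nM in a functional assay on HeLa cells (Homo sapiens) for cytotoxicity, read by MTT assay; on this read-out higher numbers stand for weaker inhibition and lower numbers for stronger inhibition
Compound 2 `CC(C)=CC[C@@H](OC(=O)C1CCCCO1)C1=CC(=O)c2c(O)ccc(O)c2C1=O` gives > 100000 nM as a limit of the assay, not a number

Compound 2 sits on the limit of > 100000 nM in this assay, at which 1 of the 2 values shown sits, and has no number of its own. Compound 3 `CCC(CO[C@H](CC=C(C)C)C1=CC(=O)c2c(O)ccc(O)c2C1=O)OC` differs from it by 2-methoxybutyl in place of (oxan-2-yl)carbonyl on an oxygen on a saturated carbon with 2-methoxybutyl in place of (oxan-2-yl)carbonyl on an oxygen on a saturated carbon, so the carbonyl leaves with the group. Within the data shown here, the only measured step, an at least 1.3-fold higher number from compound 1 to compound 2 (0.13 log units; that floor lies within the scatter), changes a group on a carbonyl carbon and keeps that carbonyl, so it sizes this change only loosely. Compound 1 at 73500 nM remains the sole numeric anchor. A modest move toward a lower number in this assay is expected, estimated as an at least 1.6-fold lower number from compound 2 to compound 3 (0.22 log units; that floor lies within the scatter), though a reading at the limit stays possible. Compound 3 is estimated at 60000 nM, with an expected range from 15000 nM to 100000 nM.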

Compound 3, half-maximal inhibitory concentration: 63500 nM
Compound 3: the middle estimate sits 1.1-fold (0.02 log units) below what was measured; the measured number falls inside the stated range.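

In this assay, the group on an oxygen on a saturated carbon can lose both its carbonyl and its ring and still give a numeric reading: 2-methoxybutyl in place of (oxolan-3-yl)carbonyl gives a 1.2-fold lower number from compound 1 to compound 3 (0.06 log units; within the scatter) and so leaves the two values inseparable. Among these compounds, with 2-methoxybutyl in place of (oxan-2-yl)carbonyl, the series shows an at least 1.5-fold lower number from compound 2 to compound 3 (0.19 log units; that floor lies within the scatter) as the only reading of that change, so its true size stays unknown. Compound 2 carries a limit, not a number: the limit of > 100000 nM in this assay, at which 1 of the 3 values shown sits.

Going by these compounds, whether any group at this oxygen can move the reading beyond the scatter of the numeric values remains open. An amine or a carboxylic acid at the end of the chain, or a longer chain in place of 2-methoxybutyl, would test this.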